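Esterifying the Acid in Two Isomeric Cinnamate Series

This account rests on a few compounds, and the source may have more. Where it says the series, first, only, none or still open, it means among the compounds named here.

Compound 1, `COc1ccc(/C=C/C(=O)O)c(OC(=O)c2nc(C)c(C)nc2C)c1`: 134000 nM
Compound 2, `COc1ccc(OC(=O)c2nc(C)c(C)nc2C)c(/C=C/C(=O)O)c1`: 49000 nM
Compound 3, `CCOC(=O)/C=C/c1ccc(OC)cc1OC(=O)c1nc(C)c(C)nc1C`: 28200 nM

All three have been measured in a functional assay on a cell-free system (Platelet, plasma, Oryctolagus cuniculus) for inhibition, with a stated time of 5 min, at 37 degrees C; a lower number here means a stronger inhibitor, a higher number a weaker inhibitor. Compound 1 and compound 3 differ in one place, (ethyl in place of hydrogen on an oxygen next to a carbonyl group), and that step gave a 4.8-fold lower number from compound 1 to compound 3 (0.68 log units; beyond the scatter). Compound 2 is built from the same atoms as compound 1, joined differently; the difference between the two cores is not broken down here. Compound 4, `CCOC(=O)/C=C/c1cc(OC)ccc1OC(=O)c1nc(C)c(C)nc1C`, has not yet been measured. It differs from compound 2 by ethyl in place of hydrogen on an oxygen next to a carbonyl group, the same change at the same place as between compound 1 and compound 3. Because the earlier step was a 4.8-fold lower number from compound 1 to compound 3 (0.68 log units; beyond the scatter), a step in the same direction, expected somewhat smaller since it rests on one example, is estimated: a 3.1-fold lower number from compound 2 to compound 4 (0.49 log units; beyond the scatter). Compound 4 is therefore expected to give about 16000 nM in this assay, likely between 5000 nM and 50000 nM.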

Compound 4, half-maximal inhibitory concentration: 196000 nM
Estimate against measurement, compound 4: 12-fold (1.09 log units) below; the whole stated range lies below it.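

Replacing the carboxy group with an ethoxycarbonyl group gave a 4.0-fold higher number from compound 2 to compound 4 (0.60 log units; beyond the scatter) and so made compound 4 the weaker inhibitor of the pair. Two pairs show that the result of this change on one core did not predict its result on the other here, but they do not show why, or how it would behave on any further core. The same change went in opposite directions on the two cores: the same change on two cores in this assay, a 4.8-fold lower number (0.68 log units; beyond the scatter) from compound 1 to compound 3 and a 4.0-fold higher number (0.60 log units; beyond the scatter) from compound 2 to compound 4, 19-fold (1.28 log units) apart, beyond the scatter of two such steps

On these data alone, whether a methyl ester or a longer chain on the same oxygen would split the two cores in the same way remains open. So does whether an amide in place of the ester would do so.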